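A few compounds are considered here, and "the series" means these few. Any claim that something is new, unique, unknown or untested is made for them only; others in the source may bear on it.

Compound 1 `C=CC[C@H]1C[C@]2([C@@H](C)Cc3cccc(OC)c3)OCOC2=CC1=O` gives 10600 nM in a functional assay on NCI-H460 cells (Homo sapiens) for antiproliferative activity, with a stated time of 72 h; on this read-out higher numbers stand for weaker inhibition and lower numbers for stronger inhibition.
Compound 2 `C=CC[C@H]1C[C@]2([C@@H](C)Cc3ccc(O)cc3)OCOC2=CC1=O` reaches only a limit of that assay, > 20000 nM.
Compound 3 `C=CC[C@H]1C[C@]2([C@@H](C)Cc3ccc(OC)nc3)OCOC2=CC1=O` gives 330 nM.

Among the numbers shown, compound 3 stands lowest; its nearest neighbour is compound 1, with a 32-fold lower number from compound 1 to compound 3 (1.51 log units; beyond the scatter). Compound 2 contributes only (the limit of > 20000 nM in this assay, at which 1 of the 3 values shown sits), so an at least 60-fold lower number from compound 2 to compound 3 (1.78 log units; beyond the scatter) is a floor rather than an exact size. Compound 4 `C=CC[C@H]1C[C@]2([C@@H](C)Cc3cnc(OC)cc3F)OCOC2=CC1=O` differs from compound 3 by fluoro in place of hydrogen on an aromatic carbon. Every measured step, including an at least 1.8-fold higher number from compound 1 to compound 2 (0.27 log units; that floor lies within the scatter), swapped the whole aromatic ring, so none tests a fluoro added to an aromatic carbon of a ring that is otherwise kept. Among the measured compounds shown here, with no close precedent, the change is expected to move this assay by no more than the scatter, giving no change at the digits printed from compound 3 to compound 4 (within the scatter). Compound 4 is therefore estimated at 330 nM, within 120 nM to 900 nM.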

Compound 4, half-maximal inhibitory concentration: > 20000 nM
Compound 4 ended at the assay's limit; the forecaster's own chance of this, stated with the estimate: 2%; at least 60-fold (1.78 log units) between middle value and limit.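

In this assay, adding a single fluoro to an aromatic carbon of an otherwise unchanged ring gives an at least 60-fold higher number from compound 3 to compound 4 (1.78 log units; beyond the scatter). This carbon, ortho to a large group and opposite the ring nitrogen, is therefore highly sensitive to even a one-atom change, something the earlier whole-ring swaps could not reveal. The size of this step is only a floor, as compound 4 reaches a limit of the assay rather than a number: the limit of > 20000 nM in this assay, at which 2 of the 4 values shown sit.

The compounds shown leave open whether a chloro or methyl group on this carbon would behave the same way. They also leave open whether fluoro on another carbon of this ring would be equally damaging.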